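Working notes on a small amide series, three measured

A few compounds are considered here, and "the series" means these few. Any claim that something is new, unique, unknown or untested is made for them only; others in the source may bear on it.

Measured in a functional assay on A549 cells (Homo sapiens) for cytotoxicity, read by MTT assay, with a stated time of 72 h; a higher number here means a weaker inhibitor, a lower number a stronger inhibitor:
compound 1 `Cc1ccc2nc(NC(=O)c3cn(-c4ccccc4)nc3-c3ccccc3)sc2c1`, 26500 nM
compound 2 `O=C(Nc1nc2ccccc2s1)c1cn(-c2ccccc2)nc1-c1ccc(Cl)cc1`, 10300 nM
compound 3 `O=C(Nc1nc2ccc(Cl)cc2s1)c1cn(-c2ccccc2)nc1-c1ccc(Cl)cc1`, 4360 nM

Compound 3 has the lowest number of the three; compound 2 is the nearest to it and compound 1 the furthest, both gaps beyond the scatter. Within the data shown here, the only single-point step inside the measured set is a 2.4-fold lower number from compound 2 to compound 3 (0.37 log units; beyond the scatter), a modest move.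

Compound 4 `Cc1ccc2nc(NC(=O)c3cn(-c4ccccc4)nc3-c3ccc(Cl)cc3)sc2c1` differs from compound 3 in one place: methyl in place of chloro on an aromatic carbon. Among the measured compounds shown here, no measured pair isolates methyl against chloro at that aromatic carbon. Compound 1 carries the methyl there, but it also differs from compound 3 at a second place, so its value cannot be split into parts. For the measured compounds named here, the only step that bears on the question is the one from compound 2 to compound 3, where chloro in place of hydrogen brought a modest gain. Swapping that chloro for methyl is expected to hand back part of that gain, not all of it, so a small rise in the number is anticipated for compound 4, a 1.6-fold higher number from compound 3 to compound 4 (0.21 log units; within the scatter). Compound 4 is estimated at 7000 nM, with a range from 3000 nM to 16000 nM.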

Compound 4, half-maximal inhibitory concentration: 18600 nM
Beside the measured number, compound 4's estimate is 2.7-fold (0.42 log units) below it, and the stated range ends below it.
By their numbers in this assay, from the lowest: compound 3; then compounds 2, 4 and 1 (each within the scatter of the next, the first and the last beyond it).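

In this assay, among these compounds, going from 6-chloro-1,3-benzothiazol-2-yl to 6-methyl-1,3-benzothiazol-2-yl gives a 4.3-fold higher number from compound 3 to compound 4 (0.63 log units; beyond the scatter), the first direct reading of methyl against chloro at this aromatic carbon, and chloro comes out ahead. Methyl in place of hydrogen at the same carbon gives a 1.8-fold higher number from compound 2 to compound 4 (0.26 log units; within the scatter), so methyl cannot be told apart from hydrogen here, and the advantage at this position so far belongs to chloro alone. Chloro in place of hydrogen on the other aromatic carbon gives a 1.4-fold lower number from compound 1 to compound 4 (0.15 log units; within the scatter), a step that cannot be told from the scatter by itself, and the two chloro steps do not differ in size beyond what repeated measurement allows: the same change on two cores in this assay, a 2.4-fold lower number (0.37 log units; beyond the scatter) from compound 2 to compound 3 and a 1.4-fold lower number (0.15 log units; within the scatter) from compound 1 to compound 4, 1.7-fold (0.22 log units) apart, within the scatter of two such steps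

The compounds shown leave open whether chloro is special at this aromatic carbon or whether other groups, such as fluoro, bromo, methoxy or an amine, would give a similar or lower number. They also leave open how far any such reading carries over to a core without the second chloro, since compound 2 and compound 4 alone cannot settle that.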